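Replacing the pyrazole with a hydroxyphenyl on the shared core

A few compounds are considered here, and "the series" means these few. Any claim that something is new, unique, unknown or untested is made for them only; others in the source may bear on it.

compound 1, `CNCCNCc1cccc(-c2nc(NC3CCOCC3)c(C)c(-c3cn(C)nc3C)n2)c1` — > 50000 nM
compound 2, `CNCCNCc1cccc(-c2nc(NC3CCOCC3)c(C)c(-c3ccnn3C)n2)c1` — > 50000 nM
compound 3, `CNCCNCc1cccc(-c2nc(NC3CCOCC3)c(C)c(-c3ccc(O)cc3)n2)c1` — to be measured

In a functional assay on BT-549 cells (Homo sapiens) for inhibition, read by sulforhodamine B assay, with a stated time of 6 days (on this read-out lower numbers stand for stronger inhibition and higher numbers for weaker inhibition), compound 1 reaches only a limit of the assay, > 50000 nM. Compound 2 likewise stops at a limit, > 50000 nM. The step that the two limits leave unreadable from compound 1 to compound 2 cannot be read because both values sit at the limit of > 50000 nM in this assay, at which 2 of the 2 values shown sit. Compound 3 differs from compound 1 by 4-hydroxyphenyl in place of 1,3-dimethyl-1H-pyrazol-4-yl on an aromatic carbon. Within the data shown here, no measured step bears on this change, so nothing points to a move beyond the scatter in this assay in either direction. Compound 3 is expected near 50000 nM, between 15000 nM and 200000 nM. For compound 3 this amounts to an expected step of a number no higher from compound 1 to compound 3 (the limit leaves the size open).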

Compound 3, half-maximal inhibitory concentration: 23700 nM
The estimate for compound 3 lay 2.1-fold (0.32 log units) above the measured number; the measured number falls inside the stated range.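

In this assay, among these compounds, 4-hydroxyphenyl gives the first readable change at this position: an at least 2.1-fold lower number from compound 1 to compound 3 (0.32 log units; beyond the scatter), and likewise an at least 2.1-fold lower number from compound 2 to compound 3 (0.32 log units; beyond the scatter). Both steps give only a minimum size because compound 1 and compound 2 each stand at a limit: the limit of > 50000 nM in this assay, at which 2 of the 3 values shown sit.

The two pyrazoles alone could not show that this position responds to the group it carries, and compound 3 now does. As far as these compounds go, whether the step comes from the hydroxyl or from the carbon-only ring stays open. A plain phenyl or a 4-methoxyphenyl on the shared core would separate the two.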